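The source may report more compounds than this note shows. Statements on the series, on what has been measured and on what is new or still open speak of the compounds shown alone.

Measured compounds:
Compound 1 `C=C1C(=O)[C@]23C[C@@]1(O)CC[C@H]2c1ccc(OS(=O)(=O)c2ccc(C)cc2)c(C)c1[C@@H]3Cn1cc(-c2ccc(Cl)cc2)nn1`, in a functional assay on HL-60 cells (Homo sapiens) for cytotoxicity, read by MTT assay, with a stated time of 4 days (a higher number here means a weaker inhibitor, a lower number a stronger inhibitor), compound 1 gives 1260 nM.
Compound 2 `C=C1C(=O)[C@]23C[C@@]1(O)CC[C@H]2c1ccc(O)c(C)c1[C@@H]3Cn1cc(-c2ccccc2)nn1`, compound 2 gives 750 nM.
Compound 3 `C=C1C(=O)[C@]23C[C@@]1(O)CC[C@H]2c1ccc(O)c(C)c1[C@@H]3Cn1cc(-c2ccc(Cl)cc2)nn1`, compound 3 gives 690 nM.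

Compound 3 has the lowest of the three numbers in this assay, but its neighbours sit close: the step of a 1.1-fold lower number from compound 2 to compound 3 (0.04 log units; within the scatter) and the step of a 1.8-fold lower number from compound 1 to compound 3 (0.26 log units; within the scatter) are both within the scatter, so no order among the three can be read from these values.

Compound 4 `C=C1C(=O)[C@]23C[C@@]1(O)CC[C@H]2c1ccc(O)c(C)c1[C@@H]3Cn1cc(-c2ccc(Br)cc2)nn1` differs from compound 3 by bromo in place of chloro on an aromatic carbon. Within the data shown here, the only measured step at the same place is the one from compound 2 to compound 3, where a chloro took the place of a hydrogen and gave a 1.1-fold lower number from compound 2 to compound 3 (0.04 log units; within the scatter); it lay within the scatter. Among the measured compounds shown here, the exchange of chloro for bromo is a smaller change than that, and no measured step speaks for a shift in either direction. Compound 4 is therefore expected to show a step of a 1.1-fold lower number from compound 3 to compound 4 (0.03 log units; within the scatter), nothing beyond the scatter. The estimate for compound 4 in this assay is 650 nM, with a range from 350 nM to 1300 nM.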

Compound 4, half-maximal inhibitory concentration: 560 nM
Beside the measured number, compound 4's estimate is 1.2-fold (0.06 log units) above it, within the range that was stated.
By their numbers in this assay, from the lowest: compounds 4, 3, 2 and 1 (each within the scatter of the next, the first and the last beyond it).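

On the aromatic carbon para to a large group, compound 4 adds a third substituent to the series, and the position still gives no readable shift in this assay. Among these compounds, neither bromo in place of chloro (a 1.2-fold lower number from compound 3 to compound 4 (0.09 log units; within the scatter)) nor bromo in place of hydrogen (a 1.3-fold lower number from compound 2 to compound 4 (0.13 log units; within the scatter)) leaves the scatter, so the single earlier step from hydrogen to chloro now has two more beside it that point to no larger change. Nothing shown here offers an explanation for these small steps.

The compounds shown carry only hydrogen and halogens at this position, so it remains open whether a methoxy group, an amine or a carboxylic acid there would shift the number beyond the scatter. It also remains open whether this flat response would hold in cell lines other than the one shown.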